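A few compounds are considered here, and "the series" means these few. Any claim that something is new, unique, unknown or untested is made for them only; others in the source may bear on it.

In a functional assay on A2780 cells (Homo sapiens) for antiproliferative activity, read by sulforhodamine B assay, with a stated time of 72 h (on this read-out lower numbers stand for stronger inhibition and higher numbers for weaker inhibition), compound 1 `COc1cccc(S(=O)(=O)c2ccc(CN/C(=N\C#N)Nc3ccncc3)cc2)c1` gives 3.4 nM, and compound 2 `N#C/N=C(\NCc1ccc(S(=O)(=O)c2cccc(C(F)(F)F)c2)cc1)Nc1ccncc1` gives 2.9 nM; the step of a 1.2-fold lower number from compound 1 to compound 2 (0.07 log units; within the scatter) stays within the scatter. Compound 3 `N#C/N=C(\NCc1ccc(S(=O)(=O)N2CC3CCC(C2)O3)cc1)Nc1ccncc1` gives 50 nM in this assay, the highest of the three numbers, and both steps leading to it, a 15-fold higher number from compound 1 to compound 3 (1.17 log units; beyond the scatter) and a 17-fold higher number from compound 2 to compound 3 (1.24 log units; beyond the scatter), lie well beyond the scatter.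

Compound 4 `N#C/N=C(\NCc1ccc(S(=O)(=O)c2cccc3cccnc23)cc1)Nc1ccncc1` differs from compound 3 in one place: a group of 10 heavy atoms (9 carbon, 1 nitrogen; one six-membered aromatic ring of carbon only, one six-membered aromatic ring with 1 hetero atom) in place of a group of 8 heavy atoms (6 carbon, 1 nitrogen, 1 oxygen; one five-membered non-aromatic ring with 1 hetero atom, one six-membered non-aromatic ring with 2 hetero atoms), on a sulfonyl sulfur. The two measured steps that bear on this change are those into compound 3, in which a six-membered aromatic ring of carbon only on the sulfonyl sulfur was exchanged for the non-aromatic bicyclic group, and each time the number rose sharply, as a 15-fold higher number from compound 1 to compound 3 (1.17 log units; beyond the scatter) and a 17-fold higher number from compound 2 to compound 3 (1.24 log units; beyond the scatter) show. The change to compound 4 runs the other way, returning an aromatic group, quinolin-8-yl, to the same sulfonyl sulfur. Going by the values given here, a large step downward in this assay is therefore expected, of a size comparable to those two steps, although no measured compound carries exactly this group, so the estimate is taken with a wide range.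

Compound 4 is expected to give about 5 nM in this assay, with a range from 2 nM to 20 nM. That estimate means an expected step of a 10-fold lower number from compound 3 to compound 4 (1.00 log units; beyond the scatter).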

Compound 4, half-maximal inhibitory concentration: 14 nM
For compound 4 the middle estimate is 2.8-fold (0.45 log units) below the measured one, and the stated range covers the measured number.
By their numbers in this assay, from the lowest: compounds 2 and 1 (each within the scatter of the next); then compound 4; then compound 3.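

Quinolin-8-yl on the sulfonyl sulfur wins back only part of what the non-aromatic bicyclic group gave up: in this assay the return to an aromatic group gives a 3.6-fold lower number from compound 3 to compound 4 (0.55 log units; beyond the scatter), a modest step where the steps into compound 3, such as a 15-fold higher number from compound 1 to compound 3 (1.17 log units; beyond the scatter), were large. Nor does an aromatic group on this sulfur by itself restore the lowest numbers, since quinolin-8-yl in place of 3-methoxyphenyl gives a 4.1-fold higher number from compound 1 to compound 4 (0.61 log units; beyond the scatter) and quinolin-8-yl in place of 3-(trifluoromethyl)phenyl gives a 4.8-fold higher number from compound 2 to compound 4 (0.68 log units; beyond the scatter). The earlier pair showed no difference among aromatic groups here, with a 1.2-fold lower number from compound 1 to compound 2 (0.07 log units; within the scatter), whereas compound 4 now shows that the choice of aromatic group on the sulfonyl sulfur can move the number beyond the scatter.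

Nothing given here accounts for any of these differences. As far as these compounds go, it remains open where an unsubstituted phenyl, a pyridin-3-yl or an open-chain diethylamino group on the same sulfur would fall, and so whether the number follows the ring system as a whole or the substituent it carries.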